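The source may hold more compounds than are shown below. What is called first, only, known or untested is meant among the compounds shown, and "the series" means these compounds.

Working notes on a small set of nucleoside analogues sharing one bicyclic core with a five-membered heteroaryl group attached. Compound 1 `O=c1[nH]cnc2c1c(-c1cccs1)cn2[C@@H]1O[C@H](CO)[C@@H](O)[C@H]1O` carries thiophen-2-yl, compound 2 `O=c1[nH]cnc2c1c(-c1ccco1)cn2[C@@H]1O[C@H](CO)[C@@H](O)[C@H]1O` carries furan-2-yl, compound 3 `Nc1nc2c(c(-c3ccco3)cn2[C@@H]2O[C@H](CO)[C@@H](O)[C@H]2O)c(=O)[nH]1` carries furan-2-yl on a core bearing an amino group, and compound 4 `Nc1nc2c(c(-c3cccs3)cn2[C@@H]2O[C@H](CO)[C@@H](O)[C@H]2O)c(=O)[nH]1` is the thiophen-2-yl partner of compound 3 and is not yet measured.

In a functional assay on HCT-116 cells (Homo sapiens), read by MTT assay, with a stated time of 72 h (a higher number here means a weaker inhibitor, a lower number a stronger inhibitor), compound 1 gives only a limit, > 20000 nM. In this assay compound 2 likewise gives only a limit, > 20000 nM. In this assay compound 3 also gives only a limit, > 20000 nM.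

The step that the two limits leave unreadable from compound 2 to compound 1 corresponds to the change (thiophen-2-yl in place of furan-2-yl on an aromatic carbon). The step that the two limits leave unreadable from compound 2 to compound 3 corresponds to the change (amino in place of hydrogen on an aromatic carbon). Neither step can be sized because of the limit of > 20000 nM in this assay, at which 3 of the 3 values shown sit.

Compound 4 differs from compound 3 by thiophen-2-yl in place of furan-2-yl on an aromatic carbon. The surroundings of the place are the same word for word as for the change from compound 2 to compound 1, so this is the same change made on a different core; the two cores differ by amino in place of hydrogen on an aromatic carbon.

With the earlier step that the two limits leave unreadable from compound 2 to compound 1 unreadable and compound 3 sitting at the limit > 20000 nM, the step that the limit leaves unreadable from compound 3 to compound 4 is expected to be flat within what can be read. Compound 4 is therefore estimated at 30000 nM, most likely reported again as a limit rather than a number.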

Compound 4, half-maximal inhibitory concentration: 19800 nM
Compound 4: the middle estimate sits 1.5-fold (0.18 log units) above what was measured; the measured number falls inside the stated range.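

In this assay, among the compounds shown here, compound 4 gives 19800 nM, the only measured number in the set, so the thiophen-2-yl for furan-2-yl change on the amino-bearing core (a number no higher from compound 3 to compound 4 (the limit leaves the size open)) ends in a number rather than a limit. Compound 3, its furan-2-yl partner, gives only a limit, > 20000 nM. The amino in place of hydrogen change on the thiophen-2-yl side (a number no higher from compound 1 to compound 4 (the limit leaves the size open)) likewise ends in a number rather than a limit. This does not show that the change has a size on either core, or that it carries over from one core to the other, and neither new step nor the earlier steps can be read, because every other value is a limit: the limit of > 20000 nM in this assay, at which 3 of the 4 values shown sit.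

The compounds shown leave open whether any group at this place gives a reading far from the limit in this assay, and whether the amino group contributes anything that can be sized. As far as these compounds go, how a phenyl group or a carboxylic acid would read on an aromatic carbon of the five-membered ring, and how a methylamino group would read in place of the amino group on the shared core, also stays open.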